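From 3,5-dimethylphenyl to 4-methoxyphenyl at one chain carbon

The source may report more compounds than this note shows. Statements on the series, on what has been measured and on what is new or still open speak of the compounds shown alone.

In a functional assay on DU-145 cells (Homo sapiens) for inhibition, read by trypan blue exclusion, with a stated time of 96 h (on this read-out lower numbers stand for stronger inhibition of growth and higher numbers for weaker inhibition of growth), compound 1 (`COc1ccccc1/C=C(\C(=O)c1ccc(Cl)cc1)S(=O)(=O)c1ccc(Br)cc1`) gives 10000 nM and compound 2 (`Cc1cc(C)cc(/C=C(\C(=O)c2ccc(Cl)cc2)S(=O)(=O)c2ccc(Br)cc2)c1`) gives 10000 nM, so compound 2 stands level with compound 1. Compound 3 (`COc1ccc(/C=C(\C(=O)c2ccc(Cl)cc2)S(=O)(=O)c2ccc(Br)cc2)cc1`) has not yet been measured. It carries 4-methoxyphenyl in place of 3,5-dimethylphenyl on a double-bonded chain carbon bound to a double-bonded chain carbon. Within the data shown here, one measured step bears on this change, an exchange of groups at the same place: no change at the digits printed from compound 1 to compound 2 (within the scatter). Among the measured compounds shown here, a 2-methoxyphenyl group is thus already represented there by compound 1 at 10000 nM, although no 4-methoxyphenyl example has been measured, so the evidence is thin. In this assay, no change beyond the scatter is expected, with an estimated 1.3-fold lower number from compound 2 to compound 3 (0.10 log units; within the scatter). For compound 3 the expected value is 8000 nM, within an estimated range of 2500 nM to 16000 nM.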

Compound 3, concentration for 50% growth inhibition: 10000 nM
Compound 3: middle estimate off by 1.3-fold (0.10 log units), on the low side, within the range that was stated.
By their numbers in this assay, from the lowest: compounds 1, 2 and 3 (each within the scatter of the next).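

In this assay the exchange of 3,5-dimethylphenyl for 4-methoxyphenyl on a double-bonded chain carbon bound to a double-bonded chain carbon gives no change at the digits printed from compound 2 to compound 3 (within the scatter), so the entry of a methoxy oxygen, counted as one hydrogen-bond acceptor, does not separate these two compounds. The two methoxyphenyl groups can now be compared directly, and the exchange of 2-methoxyphenyl for 4-methoxyphenyl gives no change at the digits printed from compound 1 to compound 3 (within the scatter), so the three groups tried at this place cannot be told apart by this read-out. No measured evidence accounts for this flat result.

On these data alone, all three compounds carry a substituted phenyl group at this place, so it remains open whether an amine, a carboxylic acid or a longer chain there would shift the number. As far as these compounds go, how changes to the 4-chlorophenyl or 4-bromophenyl groups of the shared core would read also remains open.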